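This account rests on a few compounds, and the source may have more. Where it says the series, first, only, none or still open, it means among the compounds named here.

Three compounds with the same core and different aryl amides have been measured in a functional assay on HCT-116 cells (Homo sapiens) for cytotoxicity, read by MTT assay; on this read-out higher numbers stand for weaker inhibition and lower numbers for stronger inhibition. Compound 1 `CCn1cc(C(=O)Nc2ccc(C)c([N+](=O)[O-])c2)c(=O)c2cc(F)c(N3CCNC(C)C3)c(F)c21` gives 11800 nM, compound 2 `CCn1cc(C(=O)Nc2ccc(OC)cc2)c(=O)c2cc(F)c(N3CCNC(C)C3)c(F)c21` gives 3800 nM, and compound 3 `CCn1cc(C(=O)Nc2ccc(C(C)=O)cc2)c(=O)c2cc(F)c(N3CCNC(C)C3)c(F)c21` gives 4600 nM. Compound 3 thus stands level with compound 2, as the step of a 1.2-fold higher number from compound 2 to compound 3 (0.08 log units; within the scatter) shows, and its number lies clearly under that of compound 1, as a 2.6-fold lower number from compound 1 to compound 3 (0.41 log units; beyond the scatter) shows.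

Compound 4 `CCn1cc(C(=O)Nc2ccc(OC(F)(F)F)cc2)c(=O)c2cc(F)c(N3CCNC(C)C3)c(F)c21` keeps everything except one group: trifluoromethoxy in place of acetyl on an aromatic carbon, para to a large group (trifluoromethoxy in place of acetyl on an aromatic carbon). Within the data shown here, no measured compound carries trifluoromethoxy, so no step tests this change directly. The closest guide is the exchange of methoxy for acetyl at the same carbon, a 1.2-fold higher number from compound 2 to compound 3 (0.08 log units; within the scatter), which left the number within the scatter. The larger steps, a 3.1-fold lower number from compound 1 to compound 2 (0.49 log units; beyond the scatter) and a 2.6-fold lower number from compound 1 to compound 3 (0.41 log units; beyond the scatter), both start from the 4-methyl-3-nitrophenyl amide and replace the whole aryl group, so they bear on this change less directly, though they show that the aryl group can move the number modestly. With so few compounds, the expectation in this assay is no step beyond the scatter, in either direction. The expected step is a 1.1-fold higher number from compound 3 to compound 4 (0.04 log units; within the scatter). For compound 4 the estimated value is 5000 nM, with an expected range of 2500 nM to 10500 nM.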

Compound 4, half-maximal inhibitory concentration: 2350 nM
Beside the measured number, compound 4's estimate is 2.1-fold (0.33 log units) above it; measured number outside the range, below it.
By their numbers in this assay, from the lowest: compounds 4, 2 and 3 (each within the scatter of the next); then compound 1.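

Trifluoromethoxy now joins methoxy and acetyl on the aromatic carbon para to a large group, and in this assay these three groups cannot be told apart: a 2.0-fold lower number from compound 3 to compound 4 (0.29 log units; within the scatter) and a 1.6-fold lower number from compound 2 to compound 4 (0.21 log units; within the scatter) both stay within the scatter, although the first lies close to its edge. Among these compounds, then, the number at this carbon holds within the scatter across three different groups, including the one with fluorine atoms, which neither compound 2 nor compound 3 carries. Compound 4 also stands clearly apart from compound 1, at a 5.0-fold lower number from compound 1 to compound 4 (0.70 log units; beyond the scatter), so all three compounds with a single group on the aryl ring now lie beyond the scatter from the 4-methyl-3-nitrophenyl amide, although that comparison replaces the whole aryl group.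

Nothing measured here explains these numbers or tells why compound 1 stands apart. On these data alone, it remains open whether an amine or a carboxylic acid on this carbon would move the number beyond the scatter, and whether the nitro group or the methyl group of compound 1 accounts for its gap from the others.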